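This account rests on a few compounds, and the source may have more. Where it says the series, first, only, none or still open, it means among the compounds named here.

The measured compounds and their values in an in vitro functional assay on cells for agonist activity at Bombesin receptor subtype-3 (Homo sapiens), read by luminescence and calcium flux; on this read-out higher numbers stand for an effect only at larger amounts of compound and lower numbers for an effect already at smaller amounts:
compound 1, `COc1cccc(Cc2cnc(CCc3ccc(-c4ccccc4C(=O)O)cc3)[nH]2)c1`, gives 4120 nM;
compound 2, `O=C(O)c1ccccc1-c1ccc(CCc2ncc(Cc3cccc(F)c3)[nH]2)cc1`, gives 159 nM;
compound 3, `O=C(O)c1ccccc1-c1ccc(CCc2ncc(CC3CCCCCC3)[nH]2)cc1`, gives 88 nM.

Compound 3 has the lowest number of the three in this assay, but the step of a 1.8-fold lower number from compound 2 to compound 3 (0.26 log units; within the scatter) lies within the scatter, so the two compounds of that step cannot be ranked against each other. Only compound 1 stands clearly apart, with a 47-fold lower number from compound 1 to compound 3 (1.67 log units; beyond the scatter).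

Compound 4, `O=C(O)c1ccccc1-c1ccc(CCc2ncc(Cc3cccc(Cl)c3)[nH]2)cc1`, differs from compound 3 by 3-chlorophenyl in place of cycloheptyl on a saturated chain carbon bound to an aromatic carbon. Going by the values given here, no measured step contains this exact exchange. The closest is the reverse of the step from compound 2 to compound 3, where a 3-fluorophenyl stood in place of the cycloheptyl and the number moved by a 1.8-fold lower number from compound 2 to compound 3 (0.26 log units; within the scatter), within the scatter. The step from compound 1 to compound 3, a 47-fold lower number from compound 1 to compound 3 (1.67 log units; beyond the scatter), shows that a 3-methoxyphenyl in this position gives a much higher number; compound 2 shows that a 3-fluorophenyl does not. A 3-chlorophenyl is expected to behave more like the fluoro case than the methoxy case, so compound 4 is expected to move by a 1.8-fold higher number from compound 3 to compound 4 (0.26 log units; within the scatter), which stays within the scatter. Compound 4 is therefore estimated at 160 nM, within a range of 60 nM to 450 nM.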

Compound 4, half-maximal effective concentration: 825 nM
Compound 4: middle estimate off by 5.2-fold (0.71 log units), on the low side; measured number outside the range, above it.
By their numbers in this assay, from the lowest: compounds 3 and 2 (each within the scatter of the next); then compound 4; then compound 1.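

Chloro in place of fluoro on an aromatic carbon gives a 5.2-fold higher number from compound 2 to compound 4 (0.72 log units; beyond the scatter) in this assay and so shows that this aromatic substituent matters even when one halogen replaces another, which the earlier compounds could not show. 3-Chlorophenyl in place of cycloheptyl gives a 9.4-fold higher number from compound 3 to compound 4 (0.97 log units; beyond the scatter) on the saturated chain carbon bound to an aromatic carbon, so a phenyl ring carrying a halogen does not by itself match cycloheptyl here, although compound 2, within the scatter of compound 3, goes against any rule that an aromatic ring at this position raises the number. Chloro in place of methoxy gives a 5.0-fold lower number from compound 1 to compound 4 (0.70 log units; beyond the scatter) and so places compound 4 clearly apart from compound 1 as well, with fluoro, chloro and methoxy forming an order among these three compounds only, for which the data offer no explanation.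

The compounds shown leave open where a methyl, a nitrile, a trifluoromethyl or an amine on the same phenyl ring would fall in this order. They also leave open whether cyclohexyl or cyclopentyl in place of cycloheptyl would keep the number of compound 3.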